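Bromo for Chloro on the 4-Halophenyl Group

This account rests on a few compounds, and the source may have more. Where it says the series, first, only, none or still open, it means among the compounds named here.

Measured compounds in a functional assay on MCF7 cells (Homo sapiens) for cytotoxicity, read by MTT assay, with a stated time of 4 days; a higher number here means a weaker inhibitor, a lower number a stronger inhibitor:
- compound 1 `C=C1C(=O)[C@]23C[C@@]1(O)CC[C@H]2c1ccc(OS(=O)(=O)c2ccc(C)cc2)c(C)c1[C@@H]3Cn1cc(-c2ccc(Br)cc2)nn1`: 250 nM
- compound 2 `C=C1C(=O)[C@]23C[C@@]1(O)CC[C@H]2c1ccc(OS(=O)(=O)c2ccc(C)cc2)c(C)c1[C@@H]3Cn1cc(-c2ccc(Cl)cc2)nn1`: 1440 nM
- compound 3 `C=C1C[C@]23C[C@@]1(O)CC[C@@H]2c1cccc(C)c1[C@@H]3Cn1cc(-c2ccc(Cl)cc2)nn1`: > 20000 nM, a limit of the assay, not a number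

Compound 1 and compound 2 share a core and differ only in the halogen (bromo in place of chloro on an aromatic carbon); this step gives a 5.8-fold lower number from compound 2 to compound 1 (0.76 log units; beyond the scatter). Compound 3 carries a different core; the difference between the two cores is not broken down here. Compound 3 sits at the limit of > 20000 nM in this assay, at which 1 of the 3 values shown sits.

Compound 4 `C=C1C[C@]23C[C@@]1(O)CC[C@@H]2c1cccc(C)c1[C@@H]3Cn1cc(-c2ccc(Br)cc2)nn1` is not yet measured. It differs from compound 3 by the same change, (bromo in place of chloro on an aromatic carbon). In this assay the step from compound 3 to compound 4 is expected to be of the order of an at least 1.6-fold lower number from compound 3 to compound 4 (0.22 log units; that floor lies within the scatter), resting on the step from compound 2 to compound 1 a 5.8-fold lower number from compound 2 to compound 1 (0.76 log units; beyond the scatter). Because compound 3 gives only a limit > 20000 nM, the starting point is uncertain. Compound 4 is expected at 12000 nM, between 3500 nM and 40000 nM.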

Compound 4, half-maximal inhibitory concentration: > 20000 nM
Compound 4: a limit, no number; the forecaster's own chance of this, stated with the estimate: 55%; middle value at least 1.6-fold (0.22 log units) away from the limit.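

In this assay, among the compounds shown here, compound 3 and compound 4 both sit at a limit, not a number, so no step between them can be read: the limit of > 20000 nM in this assay, at which 2 of the 4 values shown sit. Going by these compounds, whether bromo in place of chloro changes the number on the core of compound 3, as it does on the core of compound 1, stays open.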